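The source may report more compounds than this note shows. Statements on the series, on what has been measured and on what is new or still open speak of the compounds shown alone.

Compound 1 `CC(=O)Nc1ccc(S(=O)(=O)NNc2ccc(Br)cc2)cc1` carries a 4-bromophenyl on an amine nitrogen. In an assay on HeLa cells for inhibition of Indoleamine 2,3-dioxygenase 1 (Homo sapiens), read by spectrophotometry, with a stated time of 24 h (on this read-out higher numbers stand for an effect only at larger amounts of compound and lower numbers for an effect already at smaller amounts), compound 1 gives 85 nM. Compound 2 `CC(=O)Nc1ccc(S(=O)(=O)NNc2cccc(Br)c2)cc1` has the same atoms joined differently; how the two cores differ is 4-bromophenyl in place of 3-bromophenyl on an amine nitrogen. In this assay compound 2 gives 7560 nM, a step of an 89-fold higher number from compound 1 to compound 2 (1.95 log units; beyond the scatter). Compound 3 `CC(=O)Nc1ccc(S(=O)(=O)NNc2ccc(F)c(Br)c2)cc1` is derived from compound 2 by fluoro in place of hydrogen on an aromatic carbon; in this assay compound 3 gives 2490 nM, which is a 3.0-fold lower number from compound 2 to compound 3 (0.48 log units; beyond the scatter). Compound 4 `CC(=O)Nc1ccc(S(=O)(=O)NNc2ccc(Br)c(F)c2)cc1` has not yet been measured and is related to compound 1 by fluoro in place of hydrogen on an aromatic carbon. Within the data shown here, this is the same kind of change as the one from compound 2 to compound 3, but not the same: in compound 3 the fluoro enters para to a large group, while in compound 4 it enters meta to a large group. The expectation for compound 4 rests on the modest lowering a 3.0-fold lower number from compound 2 to compound 3 (0.48 log units; beyond the scatter), applied to the value of compound 1, 85 nM, with some allowance for the different surroundings. The expected step is a 1.7-fold lower number from compound 1 to compound 4 (0.23 log units; within the scatter). In this assay compound 4 is therefore expected to give about 50 nM, with a likely range from 15 nM to 200 nM.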

Compound 4, half-maximal effective concentration: 187 nM
For compound 4 the middle estimate is 3.7-fold (0.57 log units) below the measured one, and the stated range covers the measured number.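

In this assay fluoro in place of hydrogen on the core of compound 1 gives a 2.2-fold higher number from compound 1 to compound 4 (0.34 log units; beyond the scatter), so the change does not keep its earlier direction on this core. Set beside the earlier step, the same replacement moves the number in opposite directions on the two cores, and the gap is larger than repeated measurement accounts for: the same change on two cores in this assay, a 3.0-fold lower number (0.48 log units; beyond the scatter) from compound 2 to compound 3 and a 2.2-fold higher number (0.34 log units; beyond the scatter) from compound 1 to compound 4, 6.7-fold (0.82 log units) apart, beyond the scatter of two such steps. This shows that, within this series, the effect of the fluoro on the core with the 3-bromophenyl cannot simply be carried over to the core with the 4-bromophenyl, but with a single pair on each core it does not show what sets the direction or whether the reversal would recur on other cores.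

As far as these compounds go, whether a chloro or a methoxy group on the same carbon would follow the fluoro on both cores remains open. Also open, from the compounds shown here alone, is whether the contrast between the two cores would persist with a chloro or a methyl group in place of the bromo.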